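Benzyl in place of the acyl group on the ring nitrogen

The compounds below may be only part of what the source reports. "The series", "measured", "known", "first", "only" and "open" are said of these compounds alone.

The three measured compounds share one core and differ only in the group on the ring nitrogen. In an assay on isolated protein for binding affinity to secreted frizzled-related protein 1 (Homo sapiens), read by fluorescence (a lower number here means a stronger inhibitor, a higher number a weaker inhibitor), compound 1 `CC(C)(C)CC(=O)N1CCC[C@H]1C(=O)N1CCC(NS(=O)(=O)c2cc(S(=O)(=O)c3ccccc3)ccc2C(F)(F)F)CC1` gives 20 nM. Compound 2 `CN(C)CC(=O)N1CCC[C@H]1C(=O)N1CCC(NS(=O)(=O)c2cc(S(=O)(=O)c3ccccc3)ccc2C(F)(F)F)CC1` gives 90 nM in this assay, and compound 3 `O=C([C@@H]1CCCN1C(=O)c1ccncc1)N1CCC(NS(=O)(=O)c2cc(S(=O)(=O)c3ccccc3)ccc2C(F)(F)F)CC1` gives 70 nM. Compound 3 thus holds the second highest of the three numbers: its nearest neighbour is compound 2, the two lying within the scatter of each other, and the furthest is compound 1, which is clearly apart. The steps among them are a 4.5-fold higher number from compound 1 to compound 2 (0.65 log units; beyond the scatter), a 3.5-fold higher number from compound 1 to compound 3 (0.54 log units; beyond the scatter) and a 1.3-fold lower number from compound 2 to compound 3 (0.11 log units; within the scatter).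

Compound 4 `O=C([C@@H]1CCCN1Cc1ccccc1)N1CCC(NS(=O)(=O)c2cc(S(=O)(=O)c3ccccc3)ccc2C(F)(F)F)CC1` is the next variation: benzyl in place of (pyridin-4-yl)carbonyl on an amine nitrogen in a ring. All measured steps exchange only the group attached to the carbonyl carbon, so none of them speaks directly to losing the carbonyl itself; the closest guidance is that the three acyl variants span a modest range in this assay and that swapping the acyl substituent moved the number at most modestly. Without a direct precedent, a modest weakening is expected, a 1.4-fold higher number from compound 3 to compound 4 (0.15 log units; within the scatter), with wide uncertainty. Compound 4 is therefore estimated at 100 nM in this assay, with an expected range from 25 nM to 400 nM.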

Compound 4, half-maximal inhibitory concentration: 1400 nM
Compound 4: middle estimate off by 14-fold (1.15 log units), on the low side; the whole stated range lies below it.
By their numbers in this assay, from the lowest: compound 1; then compounds 3 and 2 (each within the scatter of the next); then compound 4.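

In this assay the move to benzyl gives a 20-fold higher number from compound 3 to compound 4 (1.30 log units; beyond the scatter) and so exceeds every step among the three acyl compounds; at this position, replacing the acyl group with benzyl matters more than which acyl group is carried. The comparison with the other two acyl compounds points the same way, with a 16-fold higher number from compound 2 to compound 4 (1.19 log units; beyond the scatter) and a 70-fold higher number from compound 1 to compound 4 (1.85 log units; beyond the scatter) in the same direction, so the rise does not depend on one acyl partner: neopentyl, (dimethylamino)methyl and pyridin-4-yl on the carbonyl carbon all give clearly lower numbers than benzyl on the amine nitrogen in a ring. The exchange from compound 3 removes the carbonyl and the pyridine nitrogen together, taking the group from 2 hydrogen-bond acceptors to 0, and no measurement available here explains the rise.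

Still open, going by these compounds, is whether the carbonyl or the pyridine nitrogen accounts for the difference between compound 3 and compound 4, and a benzoyl group on the same nitrogen would separate the two. Also open, on these data alone, is whether a sulfonyl group such as benzenesulfonyl can stand in for the carbonyl at this position.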